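Chlorophenyl for trifluorophenyl where every value is a limit

A few compounds are considered here, and "the series" means these few. Any claim that something is new, unique, unknown or untested is made for them only; others in the source may bear on it.

Measured so far in an ADME assay on BJ cells (Homo sapiens) for antiproliferative activity, with a stated time of 72 h; on this read-out higher numbers stand for an effect only at larger amounts of compound and lower numbers for an effect already at smaller amounts:
compound 1 `COc1ccc(-c2cc(=O)c3c(OC)cc(OC)cc3[nH]2)cc1`: > 62000 nM
compound 2 `COc1ccc(-c2cc(=O)c3c(OC)cc(OC)cc3n2S(=O)(=O)c2ccc(F)cc2)cc1`: > 65500 nM
compound 3 `COc1ccc(-c2cc(=O)c3c(OC)cc(OC)cc3n2S(=O)(=O)c2cc(F)c(F)c(F)c2)cc1`: > 65500 nM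

Compound 1 gives only a limit of the assay, > 62000 nM. Compound 2 likewise gives only a limit, > 65500 nM. Compound 3 also gives only a limit, > 65500 nM. Thus the step that the two limits leave unreadable from compound 1 to compound 2 and the step that the two limits leave unreadable from compound 2 to compound 3 cannot be read; all three values sit at limits, as the limit of > 62000 nM in this assay, at which 1 of the 3 values shown sits, and the limit of > 65500 nM in this assay, at which 2 of the 3 values shown sit, record, so compound 3 stands nowhere distinct from compound 1 or compound 2.

Compound 4 `COc1ccc(-c2cc(=O)c3c(OC)cc(OC)cc3n2S(=O)(=O)c2ccc(Cl)cc2)cc1` differs from compound 3 by 4-chlorophenyl in place of 3,4,5-trifluorophenyl on a sulfonyl sulfur. Within the data shown here, the one measured step at the same place, the step that the two limits leave unreadable from compound 2 to compound 3, is unreadable, and the other, the step that the two limits leave unreadable from compound 1 to compound 2, is unreadable too. With no readable step to lean on, and with compound 3 at > 65500 nM, the expectation is that compound 4 will again give a limit rather than a number. The expected step of a number no higher from compound 3 to compound 4 (the limit leaves the size open) is therefore none beyond the scatter. Compound 4 is expected at 65500 nM, within 20000 nM to 200000 nM.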

Compound 4, half-maximal effective concentration: > 34400 nM
Compound 4: no number, only a limit; the forecaster's own chance of this, stated with the estimate: 85%; the middle value does not contradict the limit.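

Compound 4 gives only a limit of the assay, > 34400 nM, so its steps from compound 1, compound 2 and compound 3 cannot be read. The compounds shown leave open whether any of these groups on the shared core changes the effect in this assay.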